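The compounds below may be only part of what the source reports. "The series", "measured", "known", "first", "only" and "open" are said of these compounds alone.

Values so far in a functional assay on HCT-116 cells (Homo sapiens) for inhibition; on this read-out lower numbers stand for stronger inhibition and higher numbers for weaker inhibition:
- compound 1 `CCNC(=O)c1noc(-c2cc(C(C)C)c(O)cc2O)c1-c1cc(COCC(=O)OC)no1` gives 262 nM
- compound 2 `CCNC(=O)c1noc(-c2cc(C(C)C)c(O)cc2O)c1-c1cc(CN(C)C)no1` gives 92 nM
- compound 3 `CCNC(=O)c1noc(-c2cc(C(C)C)c(O)cc2O)c1-c1cc(CN2CCCCC2)no1` gives 93 nM

Compound 3 sits level with compound 2, as a 1.0-fold higher number from compound 2 to compound 3 (0.00 log units; within the scatter) shows, and compound 1 has the higher number, as a 2.8-fold lower number from compound 1 to compound 3 (0.45 log units; beyond the scatter) shows. The next compound, compound 4 `CCNC(=O)c1noc(-c2cc(C(C)C)c(O)cc2O)c1-c1cc(C(N)=O)no1`, carries carbamoyl in place of (piperidin-1-yl)methyl on an aromatic carbon, a change counted as carbamoyl in place of (piperidin-1-yl)methyl on an aromatic carbon.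

Among the measured compounds shown here, no measured step makes this exact swap, so the guidance is loose. The nearest evidence is a 2.8-fold lower number from compound 1 to compound 2 (0.45 log units; beyond the scatter) together with a 2.8-fold lower number from compound 1 to compound 3 (0.45 log units; beyond the scatter), both modest. Compound 4 resembles compound 1 in having neither dimethylamino nor piperidin-1-yl, so a small move towards a higher number in this assay seems more likely than a move towards a lower one, though it may not clear the scatter.

The expected step is a 1.5-fold higher number from compound 3 to compound 4 (0.18 log units; within the scatter).

For compound 4 the estimated value is 140 nM with an expected range from 50 nM to 400 nM.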

Compound 4, half-maximal inhibitory concentration: 79 nM
Estimate against measurement, compound 4: 1.8-fold (0.25 log units) above; the range from low to high includes it.
By their numbers in this assay, from the lowest: compounds 4, 2 and 3 (each within the scatter of the next); then compound 1.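

On the aromatic carbon next to the ring nitrogen, this assay shows that neither dimethylamino nor piperidin-1-yl on a methyl linker is required, since carbamoyl reads level with both, with a 1.2-fold lower number from compound 3 to compound 4 (0.07 log units; within the scatter) and a 1.2-fold lower number from compound 2 to compound 4 (0.07 log units; within the scatter) as the two steps. The ((methoxycarbonyl)methoxy)methyl group remains the only one apart, with a 3.3-fold lower number from compound 1 to compound 4 (0.52 log units; beyond the scatter) being modest, so this much smaller group with no ring matches the larger amine-bearing groups and still reads clearly lower than the ester chain. Nothing measured here explains why such different groups give matching numbers.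

A nitrile or a carboxylic acid on the same aromatic carbon would help separate the part played by the carbonyl from that of the amide hydrogens in carbamoyl. A plain hydrogen there would test whether this position needs any group at all.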